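Swapping a nitro for a propanoylamino on a shared core

A few compounds are considered here, and "the series" means these few. Any claim that something is new, unique, unknown or untested is made for them only; others in the source may bear on it.

Compound 2 `O=[N+]([O-])c1ccc(-c2nc3cc(C(F)(F)F)ccc3n2C2CCCCC2)cc1` is a close relative of compound 1 `Cn1c(-c2ccc([N+](=O)[O-])cc2)nc2cc(C(F)(F)F)ccc21`. In an ADME assay on Vero cells (Chlorocebus sabaeus) for cytotoxicity (on this read-out lower numbers stand for higher toxicity in this test and higher numbers for lower toxicity in this test), compound 1 gives > 100000 nM, which is a limit of the test rather than a number. In this assay compound 2 likewise gives > 100000 nM, again a limit. Among the measured compounds shown here, the one change between them, a step that the two limits leave unreadable from compound 1 to compound 2, therefore cannot be read. Compound 2 thus sits at the limit, as the limit of > 100000 nM in this assay, at which 2 of the 2 values shown sit, shows.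

Compound 3 `CCC(=O)Nc1ccc(-c2nc3cc(C(F)(F)F)ccc3n2C2CCCCC2)cc1` differs from compound 2 in one place: propanoylamino in place of nitro on an aromatic carbon. For the measured compounds named here, no measured step follows this kind of exchange, and the only measured step, a step that the two limits leave unreadable from compound 1 to compound 2, is itself unreadable, so its size offers no guidance. In this assay the expected step for compound 3 is therefore about a number no higher from compound 2 to compound 3 (the limit leaves the size open), that is none beyond the scatter, resting only on the two limits seen so far. The estimate for compound 3 in this assay is 100000 nM, with a range from 40000 nM to 300000 nM, and the result is expected most likely to be reported once more only as a limit.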

Compound 3, half-maximal cytotoxic concentration: > 100000 nM
Compound 3: a limit, no number (the forecaster's own chance of this, stated with the estimate: 70%); the middle value lies on the limit itself.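

Among the compounds shown here, compound 3 and compound 2 are both reported in this assay only as limits, so the change from nitro to propanoylamino gives no step that can be read. Compound 1, compound 2 and compound 3 all share one limit: the limit of > 100000 nM in this assay, at which 3 of the 3 values shown sit. The compounds shown leave open whether their toxicity to these cells differs at all, and by how much.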